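Methylsulfonyl Extension of the Side Chain in Compound 4

The compounds below may be only part of what the source reports. "The series", "measured", "known", "first", "only" and "open" are said of these compounds alone.

Compound 1 `CC(C)[C@@H](CNc1ccc(OC(F)(F)F)cc1)NC(=O)[C@H](CCCc1ccccc1)CC(=O)N1CCOCC1` gives 14 nM in an assay on isolated protein for inhibition of cathepsin S (Homo sapiens); on this read-out higher numbers stand for weaker inhibition and lower numbers for stronger inhibition. Compound 2 `CC[C@@H](CNc1ccc(OC(F)(F)F)cc1)NC(=O)[C@@H](CC(=O)N1CCOCC1)CC1CCCCC1` gives 16 nM in this assay, and compound 3 `CC(C)[C@@H](CNc1ccc(OC(F)(F)F)cc1)NC(=O)[C@@H](CC(=O)N1CCOCC1)CC1CCCC1` gives 38 nM in this assay. Among these three numbers compound 2 stands second highest; its value and that of compound 1 lie within the scatter of each other, while the value of compound 3 sits beyond it. For the measured compounds named here, the only single-point step in the set runs a 2.7-fold higher number from compound 1 to compound 3 (0.43 log units; beyond the scatter); it concerns cyclopentyl in place of phenethyl on a saturated chain carbon, two bonds along the chain from a carbonyl carbon, a different part of the shared core from the one altered here. Going by the values given here, compound 1 and compound 2 differ in two places at once, so their values show only that the two changes together leave the number within the scatter.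

Compound 4 `CS(=O)(=O)CC[C@@H](CNc1ccc(OC(F)(F)F)cc1)NC(=O)[C@@H](CC(=O)N1CCOCC1)CC1CCCCC1` is not yet measured. Relative to compound 2 the change is methylsulfonyl in place of hydrogen on a saturated chain carbon, three bonds along the chain from an amide-type nitrogen. Among the compounds with values here, no measured step touches the saturated chain carbon three bonds along the chain from an amide-type nitrogen, so there is no precedent for methylsulfonyl at this place. With nothing to guide the direction, the expected step in this assay is a 1.3-fold higher number from compound 2 to compound 4 (0.10 log units; within the scatter), not beyond the scatter, with a wide range allowed. Compound 4 is therefore estimated at 20 nM, between 6 nM and 70 nM.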

Compound 4, inhibition constant: 5 nM
Estimate against measurement, compound 4: 4.0-fold (0.60 log units) above, and the stated range ends above it.
By their numbers in this assay, from the lowest: compound 4; then compounds 1 and 2 (each within the scatter of the next); then compound 3.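

Working notes on the side chain: in this assay the saturated chain carbon three bonds along the chain from an amide-type nitrogen accepts methylsulfonyl, and the change from ethyl to 2-(methylsulfonyl)ethyl gives a 3.2-fold lower number from compound 2 to compound 4 (0.51 log units; beyond the scatter) as its step. For the compounds shown here, this is the first reading at this place, and the added 4 heavy atoms, with no ring and no net charge, go with stronger inhibition rather than weaker; the only earlier single-point step, a 2.7-fold higher number from compound 1 to compound 3 (0.43 log units; beyond the scatter), concerns a different part of the shared core. Nothing in the data on this series bears on what lies behind the lower number for compound 4.

Still open, on these data alone, is whether the step follows the methylsulfonyl group itself or the longer chain alone, a question that a plain butyl chain or a 2-(methylthio)ethyl group at this place would address. Also open, as far as these compounds go, is whether the same change gives a step of like size with cyclopentyl or phenethyl in place of the cyclohexylmethyl side chain, and whether an amine or a carboxylic acid at the end of this chain reads the same way.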